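Compound 4: a second fluoro on the 2-fluorophenyl group

The source may report more compounds than this note shows. Statements on the series, on what has been measured and on what is new or still open speak of the compounds shown alone.

compound 1 `Nc1ccccc1NC(=O)c1ccc(CNC(=O)c2n[nH]cc2NC(=O)c2ccccc2)cc1` gives 4060 nM
compound 2 `Nc1ccccc1NC(=O)c1ccc(CNC(=O)c2n[nH]cc2NC(=O)c2c(Cl)cccc2Cl)cc1` gives 1830 nM
compound 3 `Nc1ccccc1NC(=O)c1ccc(CNC(=O)c2n[nH]cc2NC(=O)c2ccccc2F)cc1` gives 3440 nM

All three values stem from a functional assay on HeLa cells (Homo sapiens) for inhibition, read by CCK-8 assay, with a stated time of 72 h (on this read-out higher numbers stand for weaker inhibition and lower numbers for stronger inhibition), alone. Compound 3 holds the middle place among the three numbers but stands within the scatter of both others, with a 1.2-fold lower number from compound 1 to compound 3 (0.07 log units; within the scatter) on one side and a 1.9-fold higher number from compound 2 to compound 3 (0.27 log units; within the scatter) on the other. Compound 4 `Nc1ccccc1NC(=O)c1ccc(CNC(=O)c2n[nH]cc2NC(=O)c2c(F)cccc2F)cc1` differs from compound 3 by fluoro in place of hydrogen on an aromatic carbon as fluoro in place of hydrogen on an aromatic carbon, so that 2-fluorophenyl becomes 2,6-difluorophenyl. Among the compounds with values here, the closest precedent is the first fluoro, where a 1.2-fold lower number from compound 1 to compound 3 (0.07 log units; within the scatter) stays inside the scatter. The other relevant measurement is a 2.2-fold lower number from compound 1 to compound 2 (0.35 log units; beyond the scatter) for 2,6-dichlorophenyl, a modest step and the only one beyond the scatter, though it involves chloro rather than fluoro. In this assay the expectation is therefore no step beyond the scatter, with a slight lean towards a lower number. The estimated step is a 1.2-fold lower number from compound 3 to compound 4 (0.07 log units; within the scatter) and stays small. Compound 4 is expected at 2900 nM with an estimated range from 1500 nM to 5000 nM in this series.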

Compound 4, half-maximal inhibitory concentration: 4480 nM
For compound 4 the middle estimate is 1.5-fold (0.19 log units) below the measured one; the measured number falls inside the stated range.
By their numbers in this assay, from the lowest: compounds 2, 3, 1 and 4 (each within the scatter of the next, the first and the last beyond it).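

In this assay a second fluoro on the 2-fluorophenyl group gives no step beyond the scatter (a 1.3-fold higher number from compound 3 to compound 4 (0.11 log units; within the scatter)), and 2,6-difluorophenyl also stays within the scatter of the unsubstituted phenyl (a 1.1-fold higher number from compound 1 to compound 4 (0.04 log units; within the scatter)). The two dihalogenated compounds, however, lie beyond the scatter of each other (a 2.4-fold higher number from compound 2 to compound 4 (0.39 log units; beyond the scatter)), so the modest step from phenyl to 2,6-dichlorophenyl does not carry over to 2,6-difluorophenyl, and at this position the identity of the halogen matters more than the count of substituents in these compounds. No measurement at hand bears on the reason for this difference.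

Open, as far as these compounds go, is whether a methoxy group, an amine or a carboxylic acid in place of fluoro on this phenyl would move the number beyond the scatter. Also open, from the compounds shown here alone, is whether a single chloro, as 2-chlorophenyl, would fall nearer to compound 2 or to compound 3.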